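Ring Size Change in an Amide at the Stability Limit

The source may hold more compounds than are shown below. What is called first, only, known or untested is meant among the compounds shown, and "the series" means these compounds.

In an ADME assay on microsomes from liver (Rattus norvegicus) for metabolic stability, read by LC-MS, using NADPH, with a stated time of 30 min, tested at 0.1 uM, in the presence of a further agent that is not named here (a higher number here means that more of the compound is left, a lower number that less of the compound is left), compound 1 `Nc1ncc(-c2ccc(C(=O)N3CCC(O)CC3)cc2)nc1-c1ccc(C(F)(F)F)cc1` gives > 90%, which is a limit rather than a number. Compound 2 `NC(=O)c1ccc(-c2cnc(N)c(-c3ccc(C(F)(F)F)cc3)n2)cc1` likewise gives > 90%, again a limit. Compound 3 `Nc1ncc(-c2ccc(C(=O)N3CC(O)C3)cc2)nc1-c1ccc(C(F)(F)F)cc1` gives > 90%, also a limit. Because of the limit of > 90% in this assay, at which 3 of the 3 values shown sit, none of the steps between them can be read: a step that the two limits leave unreadable from compound 1 to compound 2, a step that the two limits leave unreadable from compound 1 to compound 3 and a step that the two limits leave unreadable from compound 2 to compound 3 all stay hidden. Compound 3 therefore stands where every measured compound stands, at the limit, with nothing that separates it from the others.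

Compound 4 `Nc1ncc(-c2ccc(C(=O)N3CC[C@@H](O)C3)cc2)nc1-c1ccc(C(F)(F)F)cc1` differs from compound 3 in one place: 3-hydroxypyrrolidin-1-yl in place of 3-hydroxyazetidin-1-yl on a carbonyl carbon. The three measured steps bear on this change, and each is unreadable, so their size gives no guide beyond showing that two other groups on the same carbonyl carbon left the compound at the limit. No step beyond the usual scatter is therefore expected in this assay, in either direction. Compound 4 is expected to give 92%, within 78% to 100%, most likely reported once more as a limit, a step that the limit leaves unreadable from compound 3 to compound 4 that is expected to lie within the scatter.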

Compound 4, percent of the compound remaining in the Rattus norvegicus assay: > 90%
Compound 4: only a limit was reported; the forecaster's own chance of this, stated with the estimate: 85%; the middle value is on the limit's open side.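

No new step can be read for compound 4 against compounds 1, 2 or 3 in the Rattus norvegicus assay, because every compound shown stands at one limit: the limit of > 90% in the Rattus norvegicus assay, at which 4 of the 4 values shown sit.

In a physicochemical assay for solubility, read by HPLC, using the shake flask method, with a stated time of 2 h, at pH 2 (a lower number here means a less soluble compound, a higher number a more soluble compound), compound 3 gives 110000 nM and compound 4 gives 103000 nM, which is a 1.1-fold lower number from compound 3 to compound 4 (0.03 log units; within the scatter).

The compounds shown leave open whether the group on the carbonyl carbon changes the percent remaining in the Rattus norvegicus assay at all.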